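The source may report more compounds than this note shows. Statements on the series, on what has been measured and on what is new or still open speak of the compounds shown alone.

In a functional assay on the whole organism (Tail, strain ICR) with Mus musculus as the target, in the tail flick test, with a stated time of 30 min, at a dose of 25 umol/kg by the oral route (on this read-out higher numbers stand for a stronger effect at the one dose given and lower numbers for a weaker effect), compound 3, `O=C(CN(c1nc(Cl)nc2[nH]cnc12)C1CC1)N[C@@H](CCC(=O)OCc1ccccc1)C(=O)OCc1ccccc1`, gives 52.8%, the highest of the three numbers measured, though compound 1, `C[C@H](NC(=O)CN(c1nc(Cl)nc2[nH]cnc12)C1CC1)C(=O)O`, with 48.1% sits within the scatter of it, and only compound 2, `CC(C)C[C@H](NC(=O)CN(c1nc(Cl)nc2[nH]cnc12)C1CC1)C(=O)OCc1ccccc1`, with 33.9% lies beyond the scatter below it. Within the data shown here, the one measured step, a number 18.9 percentage points higher from compound 2 to compound 3 (beyond the scatter), is the only guide to how this side chain bears on the read-out in this assay, and it shows that an exchange at this position can move the number by a modest but real amount.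

Compound 4, `C[C@H](NC(=O)CN(c1nc(Cl)nc2[nH]cnc12)C1CC1)C(=O)OCc1ccccc1`, is reached from compound 3 by hydrogen in place of (benzyloxycarbonyl)methyl on a saturated chain carbon, two bonds along the chain from an amide-type nitrogen and a carbonyl carbon. Among the measured compounds shown here, the same position has carried isopropyl and (benzyloxycarbonyl)methyl so far, never hydrogen, so the direction is not fixed by the data; the one measured step went up when the larger group entered. On that basis compound 4 is expected to fall somewhat below compound 3, with a step of about a number 10.8 percentage points lower from compound 3 to compound 4 (beyond the scatter) in this assay, though a result within the scatter of compound 3 would not be surprising. The estimate for compound 4 in this assay is 42%, with a range from 25% to 60%.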

Compound 4, a percentage reported as activity, at one dose (the size of the read-out at that dose, not a potency): 41.2%
Estimate against measurement, compound 4: 0.8 percentage points above; the measured number falls inside the stated range.
By their numbers in this assay, from the lowest: compounds 2, 4, 1 and 3 (each within the scatter of the next, the first and the last beyond it).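

Hydrogen gives this saturated chain carbon a third substituent to compare in this assay: with a number 11.6 percentage points lower from compound 3 to compound 4 (beyond the scatter), removing (benzyloxycarbonyl)methyl gives back a step of modest size, close to the one seen when that group replaced isopropyl. The comparison with isopropyl adds something new, since a number 7.3 percentage points higher from compound 2 to compound 4 (within the scatter) leaves hydrogen and isopropyl within the scatter of each other, so among these three compounds only (benzyloxycarbonyl)methyl stands apart, and neither a larger alkyl group nor its absence does. The second change, benzyl in place of hydrogen on an oxygen next to a carbonyl group, gives a number 6.9 percentage points lower from compound 1 to compound 4 (within the scatter) and so cannot be told from the scatter at this one dose.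

On these data alone, whether a carboxylic acid or an amine at the end of a longer chain on this carbon would behave like (benzyloxycarbonyl)methyl or like hydrogen remains open, and so does whether the benzyl ester within that group matters for the step. Nothing available here explains why this group stands apart from hydrogen and isopropyl.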